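The compounds below may be only part of what the source reports. "The series", "measured", "known", "first", "only" and "open" are said of these compounds alone.

- Compound 1 `CCCN(C)c1nc(Cc2c(F)cccc2F)cc(=O)[nH]1`: 85000 nM
- Compound 2 `O=c1cc(Cc2c(F)cccc2F)nc(N2CCCC2)[nH]1`: > 86000 nM, a limit
- Compound 3 `O=c1cc(Cc2c(F)cccc2F)nc(N2CCCCC2)[nH]1`: > 82000 nM, a limit

All three compounds were tested in an ADME assay on MT4 cells (Homo sapiens) for cytotoxicity, read by MTT assay, with a stated time of 4 days; on this read-out lower numbers stand for higher toxicity in this test and higher numbers for lower toxicity in this test. Compound 3 has no exact number and is known only by a limit, (the limit of > 82000 nM in this assay, at which 1 of the 3 values shown sits). Compound 2 is likewise known only by a limit, (the limit of > 86000 nM in this assay, at which 1 of the 3 values shown sits). Compound 4 `CC1CCCCN1c1nc(Cc2c(F)cccc2F)cc(=O)[nH]1` differs from compound 3 by methyl in place of hydrogen on a saturated ring carbon, next to the ring nitrogen, which turns piperidin-1-yl into 2-methylpiperidin-1-yl.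

Among the measured compounds shown here, three measured steps bear on this change, each swapping the amine group on the shared core: an at least 1.0-fold higher number from compound 1 to compound 2 (0.00 log units; that floor lies within the scatter), a step that the limit leaves unreadable from compound 1 to compound 3 and a step that the two limits leave unreadable from compound 2 to compound 3. None of them shows a readable change beyond the scatter. For the measured compounds named here, the only exact number in the set is that of compound 1, at 85000 nM. No step beyond the scatter is therefore expected in this assay, and compound 4 may again return only a limit. For compound 4 the estimated value is 78000 nM, with an expected range from 35000 nM to 110000 nM.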

Compound 4, half-maximal cytotoxic concentration: > 78000 nM
Compound 4: a limit, no number (the forecaster's own chance of this, stated with the estimate: 65%); the middle value sits exactly at the limit.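

In this assay compound 4 gives > 78000 nM, which is a limit and not a number, and none of its steps from compound 1, compound 2 or compound 3 can be read. The compounds shown leave open whether any of these amine groups on the shared core changes the read-out beyond the scatter.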